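The source may hold more compounds than are shown below. What is called first, only, known or untested is meant among the compounds shown, and "the series" means these compounds.

Working notes on a series of aryl ureas sharing one core. Compound 1, `CCN(CC)CCn1cnnc1-c1cc(Oc2ccc(NC(=O)Nc3cccc(C(F)(F)F)c3)cc2F)ccn1`, gives 6920 nM in an ADME assay on WI-38 cells (Homo sapiens) for cytotoxicity, read by MTT assay, with a stated time of 72 h; on this read-out lower numbers stand for stronger inhibition and higher numbers for weaker inhibition. Compound 3, `CCN(CC)CCn1cnnc1-c1cc(Oc2ccc(NC(=O)Nc3ccc(F)c(Cl)c3)cc2F)ccn1`, gives 28700 nM in this assay. Compound 2, `CCN(CC)CCn1cnnc1-c1cc(Oc2ccc(NC(=O)Nc3ccc(F)c(F)c3)cc2F)ccn1`, returns only a limit in this assay, > 50000 nM, and no number; this is the limit of > 50000 nM in this assay, at which 1 of the 3 values shown sits. Of the two numbers that exist, compound 3 holds the higher one, with compound 1 as its nearest neighbour at a clearly lower number. The measured steps all change the aryl group on the amide-type nitrogen: an at least 7.2-fold higher number from compound 1 to compound 2 (0.85 log units; beyond the scatter); a 4.1-fold higher number from compound 1 to compound 3 (0.62 log units; beyond the scatter); an at least 1.7-fold lower number from compound 2 to compound 3 (0.24 log units; that floor lies within the scatter). None of them touches the saturated chain two bonds from the aromatic nitrogen, which is where the next compound varies.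

Compound 4, `CN(C)CCCn1cnnc1-c1cc(Oc2ccc(NC(=O)Nc3ccc(F)c(Cl)c3)cc2F)ccn1`, differs from compound 3 in that chain only: (dimethylamino)methyl in place of diethylamino on a saturated chain carbon, two bonds along the chain from an aromatic nitrogen. Among the compounds with values here, no measured step bears on this change, since every step in hand sits on the aryl group of the urea, and nothing shows what the amine-bearing chain does in this assay. The step from compound 3 to compound 4 is therefore expected to be none beyond the scatter, a 1.0-fold lower number from compound 3 to compound 4 (0.01 log units; within the scatter). Compound 4 is estimated at 28000 nM in this assay, with a range from 9000 nM to 60000 nM.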

Compound 4, half-maximal inhibitory concentration: 5370 nM
The estimate for compound 4 lay 5.2-fold (0.72 log units) above the measured number; measured number outside the range, below it.
By their numbers in this assay, from the lowest: compounds 4 and 1 (each within the scatter of the next); then compound 3. At a limit, above all of these: compound 2.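

Changing the 2-(diethylamino)ethyl chain to 3-(dimethylamino)propyl gives a 5.3-fold lower number from compound 3 to compound 4 (0.73 log units; beyond the scatter), so the amine-bearing chain moves the number in this assay by a step beyond the scatter, with the 3-chloro-4-fluorophenyl urea held fixed. Within the data shown here, until now, the only steps in hand sat on the aryl group of the urea, such as a 4.1-fold higher number from compound 1 to compound 3 (0.62 log units; beyond the scatter); this position now counts as a second place where the number shifts. Nothing measured in the series explains why this chain change lowers the number.

The change alters the substituents on the amine and the length of the chain at once, and the compounds shown do not separate the two, which a 2-(dimethylamino)ethyl or a 3-(diethylamino)propyl chain would do. Also open, going by these compounds, are whether the step carries over to the 3-(trifluoromethyl)phenyl urea of compound 1, and what a ring amine such as morpholine or pyrrolidine does at the end of this chain.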